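This account rests on a few compounds, and the source may have more. Where it says the series, first, only, none or still open, it means among the compounds named here.

Compound 2, `C[C@H]1COC[C@H](C)N1c1c(NC(=O)Nc2ccnc(C(F)(F)F)c2)cnc2cc(Cl)nn12`, in an ADME assay on microsomes from liver (Rattus norvegicus) for metabolic stability (on this read-out lower numbers stand for slow clearance and higher numbers for fast clearance), gives 42 mL.min-1.g-1, the lowest of the two numbers shown, although compound 1, `O=C(Nc1cnc(-n2nccn2)c(Cl)c1)Nc1cnc2cc(Cl)nn2c1C1CC1`, gives 50.4 mL.min-1.g-1 in this assay, a difference within the scatter. Compound 3, `CO[C@H](C)c1c(NC(=O)Nc2cnc(-n3nccn3)c(Cl)c2)cnc2cc(Cl)nn12`, gives only a limit in this assay, < 25 mL.min-1.g-1, and (the limit of < 25 mL.min-1.g-1 in this assay, at which 1 of the 3 values shown sits). Among the compounds with values here, the one measured step is an at least 2.0-fold lower number from compound 1 to compound 3 (0.30 log units; that floor lies within the scatter), a change at a different place on the shared core. Compound 4, `Cc1c(NC(=O)Nc2ccnc(C(F)(F)F)c2)cnc2cc(Cl)nn12`, differs from compound 2 in one place: methyl in place of 3,5-dimethylmorpholin-4-yl on an aromatic carbon. Within the data shown here, no measured step shows this change, so no shift beyond the scatter is expected, and the estimate for compound 4 in this assay is 42 mL.min-1.g-1, from 20 mL.min-1.g-1 to 85 mL.min-1.g-1, an expected step of no change at the digits printed from compound 2 to compound 4 (within the scatter).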

Compound 4, intrinsic clearance in microsomes: < 25 mL.min-1.g-1
Compound 4: a limit, no number (the forecaster's own chance of this, stated with the estimate: 20%); at least 1.6-fold (0.22 log units) between middle value and limit.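

In this assay, methyl in place of 3,5-dimethylmorpholin-4-yl on this aromatic carbon gives an at least 1.6-fold lower number from compound 2 to compound 4 (0.22 log units; that floor lies within the scatter). Going by these compounds, compound 4 gives a limit rather than a number, so the true size of this step stays unknown, and the floor alone does not pass the scatter. The large ring is therefore not required at this position to reach the low end of the read-out, where compound 4 now joins compound 3: the limit of < 25 mL.min-1.g-1 in this assay, at which 2 of the 4 values shown sit.

The compounds shown leave open where an amine or a longer alkyl chain at this position would fall on this read-out.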